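The source may report more compounds than this note shows. Statements on the series, on what has been measured and on what is new or still open speak of the compounds shown alone.

Going by the values given here, compound 2 `COc1cc(C(=O)Nc2nn[nH]n2)nc(-c2ccc(NC(C)=O)cc2)c1` is one of three compounds measured in a functional assay on the whole organism with Rattus norvegicus as the target, at a dose of 3 mg/kg by the oral route; on this read-out lower numbers stand for a weaker effect and higher numbers for a stronger effect at the one dose given. In this assay compound 2 gives 27%, the second highest of the three numbers. Compound 3 `Cc1ccc(-c2cccc(C(=O)Nc3nn[nH]n3)n2)cc1C` gives 28%, within the scatter of compound 2, while compound 1 `COc1cc(C(=O)Nc2nn[nH]n2)nc(-c2ccc(Cl)cc2)c1` gives 12%; the step of a number 15 percentage points higher from compound 1 to compound 2 (beyond the scatter) was modest and placed an acetamido where a chloro had been on an aromatic carbon. Compound 4 `CC(=O)Nc1ccc(-c2cc(C)cc(C(=O)Nc3nn[nH]n3)n2)cc1` differs from compound 2 in one place: methyl in place of methoxy on an aromatic carbon. Among the compounds with values here, no measured step involves a methyl in place of a methoxy, so the step from compound 1 to compound 2 offers no guide here. A step of no more than the scatter is therefore expected in this assay, in either direction. For compound 4 the estimate is 27%, with a range from 10% to 45%. This means an expected step of no change at the digits printed from compound 2 to compound 4 (within the scatter).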

Compound 4, a percentage reported as inhibition, in the whole organism at one dose (the size of the read-out at that dose, not a potency): 32%
Compound 4: middle estimate off by 5 percentage points, on the low side; the measured number falls inside the stated range.
By their numbers in this assay, from the lowest: compound 1; then compounds 2, 3 and 4 (each within the scatter of the next).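

In this assay, putting methyl in place of methoxy opposite the ring nitrogen gives a number 5 percentage points higher from compound 2 to compound 4 (within the scatter). This position therefore tolerates the loss of the methoxy oxygen, with its one hydrogen-bond acceptor, without a change that rises above the scatter. At this single dose, the read-out does not separate the two groups.

From the compounds shown here alone, whether an amine or a longer chain such as ethoxy at this place would move the number beyond the scatter remains open. No supporting measurement explains why methyl and methoxy read alike.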